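Benzyl for methyl on a chlorinated dihydropyran core

A few compounds are considered here, and "the series" means these few. Any claim that something is new, unique, unknown or untested is made for them only; others in the source may bear on it.

Compound 1 `CC(C)CC1C=C(Cl)CCO1` in a functional assay on A2780 cells (Homo sapiens) for antiproliferative activity (a lower number here means a stronger inhibitor of growth, a higher number a weaker inhibitor of growth), gives > 100000 nM, a limit of the assay.
Compound 2 `CCC(C)[C@H]1O[C@@H](C)CC(Cl)=C1[Si](C)(C)C` in this assay gives > 100000 nM, also a limit.
Compound 3 `C[C@H]1CC(Cl)=C([Si](C)(C)C)[C@@H](C2CCCCC2)O1` in this assay gives 17000 nM.

Within the data shown here, compound 3 thus holds the only real number among the three, and it stands apart from the two limit values the limit of > 100000 nM in this assay, at which 2 of the 3 values shown sit, through the step of an at least 5.8-fold lower number from compound 2 to compound 3 (0.76 log units; beyond the scatter). Compound 4 `C[Si](C)(C)C1=C(Cl)C[C@H](Cc2ccccc2)O[C@@H]1C1CCCCC1` keeps the core of compound 3 and differs only by phenyl in place of hydrogen on a saturated chain carbon bound to a saturated ring carbon. No measured step touches that chain carbon: the one step shown, from compound 2 to compound 3, concerns the cyclohexyl group, so it gives no guide to the new position. In this assay compound 4 is therefore expected to move little, a 1.4-fold lower number from compound 3 to compound 4 (0.15 log units; within the scatter), with an estimate of 12000 nM in the range 3000 nM to 50000 nM.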

Compound 4, concentration for 50% growth inhibition: 34000 nM
For compound 4 the middle estimate is 2.8-fold (0.45 log units) below the measured one; measured number inside the range.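

In this assay, methyl to benzyl on the shared core gives a 2.0-fold higher number from compound 3 to compound 4 (0.30 log units; within the scatter), so this chain carbon takes a whole phenyl with no change that can be told from repeat measurements. Among these compounds, this is the first reading at this position, as the earlier step concerned only the cyclohexyl group. Like compound 3, compound 4 gives a real number and stays clear of one mark: the limit of > 100000 nM in this assay, at which 2 of the 4 values shown sit.

The compounds shown leave open whether an amine, a carboxylic acid or a longer chain at this carbon would move the number. They also leave open whether a substituted phenyl would do so.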